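The compounds below may be only part of what the source reports. "The series", "measured", "known", "first", "only" and "open" are said of these compounds alone.

Compound 3 `Cc1nn2cc(-c3cc4ccccc4o3)nc2s1` stands at the edge of an assay for antagonist activity at proteinase-activated receptor 4 (Homo sapiens), with stated times of 5 min, 50 s and 15 min, in the presence of a further agent that is not named here; a higher number here means a weaker inhibitor, a lower number a stronger inhibitor: in this assay compound 3 gives > 30000 nM, which is a limit of the assay and not a number. Compound 1 `CS(=O)(=O)c1nn2cc(-c3cc4ccccc4o3)nc2s1` in this assay gives > 30000 nM, again a limit. For the measured compounds named here, compound 2 `COc1nn2cc(-c3cc4ccccc4o3)nc2s1` is the one measured compound with a number, giving 240 nM in this assay. Two of the three values shown are limits, (the limit of > 30000 nM in this assay, at which 2 of the 3 values shown sit). The step from compound 3 to compound 4 `CCOc1nn2cc(-c3cc4ccccc4o3)nc2s1` is ethoxy in place of methyl on an aromatic carbon. Of the measured steps, an at least 120-fold higher number from compound 2 to compound 3 (2.09 log units; beyond the scatter) exchanges methoxy for methyl at that carbon and bears on it most directly, and an at least 120-fold lower number from compound 1 to compound 2 (2.09 log units; beyond the scatter) also ends at the methoxy compound. a step that the two limits leave unreadable from compound 1 to compound 3. Compound 4 shares with compound 2 an alkoxy group at that carbon, so a large drop in the number in this assay is expected, estimated as an at least 60-fold lower number from compound 3 to compound 4 (1.77 log units; beyond the scatter). Compound 4 is therefore estimated at 500 nM, with a range from 100 nM to 5000 nM.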

Compound 4, half-maximal inhibitory concentration: 2100 nM
Estimate against measurement, compound 4: 4.2-fold (0.62 log units) below, and the stated range covers the measured number.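

In this assay a second alkoxy group at this carbon also gives a measured number, with an at least 14-fold lower number from compound 3 to compound 4 (1.15 log units; beyond the scatter) and an at least 14-fold lower number from compound 1 to compound 4 (1.15 log units; beyond the scatter) in the same direction as the step to the methoxy compound, so a readable number here is not peculiar to methoxy. For the compounds shown here, the length of the alkoxy group also counts: an 8.8-fold higher number from compound 2 to compound 4 (0.94 log units; beyond the scatter) is the only new step with a number at both ends, and it shows that the added methyl on the chain carbon bound to the oxygen does not leave the number unchanged. The other two steps give only a minimum size, as each starts from a limit of the assay and not a number: the limit of > 30000 nM in this assay, at which 2 of the 4 values shown sit.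

From the compounds shown here alone, whether a longer chain such as propoxy would raise the number further remains open. So does whether an amine at this carbon would behave like the alkoxy groups.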